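The source may hold more compounds than are shown below. What is called first, only, known or untested is meant among the compounds shown, and "the series" means these compounds.

Compound 1 `O=S1(=O)C=C(Sc2nnc(-c3cccnc3)o2)c2ccccc21` and compound 2 `O=S1(=O)C=C(Sc2nnc(-c3ccccc3Cl)o2)c2ccccc21` share one core and differ only in the aromatic ring attached to it. In an ADME assay on HEK293 cells (Homo sapiens) for cytotoxicity, read by fluorescence and resazurin assay, with a stated time of 24 h (a higher number here means that more compound is tolerated, a lower number that less compound is tolerated), compound 1 gives 4000 nM, and compound 2 gives 4000 nM. The step of no change at the digits printed from compound 1 to compound 2 (within the scatter) shows that exchanging 2-chlorophenyl for pyridin-3-yl at that place moved nothing; compound 1 therefore stands level with compound 2 in this assay, within the scatter. Compound 3 `COc1ccc(-c2nnc(SC3=CS(=O)(=O)c4ccccc43)o2)cc1` carries the change (4-methoxyphenyl in place of pyridin-3-yl on an aromatic carbon). Among the compounds with values here, only that one measured step bears on this change, since it is the sole exchange of the ring at the same position, and it was flat. Because the step of no change at the digits printed from compound 1 to compound 2 (within the scatter) was within the scatter, compound 3 is expected to show no step beyond the scatter either, so no change at the digits printed from compound 1 to compound 3 (within the scatter) is estimated to be small. Compound 3 is estimated at 4000 nM, in a range from 1500 nM to 10000 nM.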

Compound 3, half-maximal cytotoxic concentration: 2000 nM
Estimate against measurement, compound 3: 2.0-fold (0.30 log units) above; the range from low to high includes it.
By their numbers in this assay, from the lowest: compounds 3, 1 and 2 (each within the scatter of the next).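

In this assay the change to 4-methoxyphenyl gives a 2.0-fold lower number from compound 1 to compound 3 (0.30 log units; within the scatter) and also a 2.0-fold lower number from compound 2 to compound 3 (0.30 log units; within the scatter), so neither step can be read as a real shift. This position, on an aromatic carbon of the five-membered aromatic ring, has now carried pyridin-3-yl, 2-chlorophenyl and 4-methoxyphenyl with all three compounds within the scatter of one another, which extends the flat result from a single exchange to three six-membered aromatic rings. Nothing available here offers an explanation for this result.

On these data alone, whether a group other than such a ring at this place, such as an amine, a carboxylic acid or a longer alkyl chain, would give a step beyond the scatter remains open. As far as these compounds go, all three compounds also share the same core, so the effect of any change elsewhere on it is unknown.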